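A few compounds are considered here, and "the series" means these few. Any claim that something is new, unique, unknown or untested is made for them only; others in the source may bear on it.

Two compounds share one core that ends in a ketone. Compound 1 `O=C(CCCCCCc1ccccc1)c1nc(Br)co1` carries a bromo group on an aromatic carbon, and in an assay on isolated protein for inhibition of Fatty-acid amide hydrolase 1 (Rattus norvegicus) (a higher number here means a weaker inhibitor, a lower number a stronger inhibitor), compound 1 gives 3 nM. Compound 2 `CNC(=O)c1coc(C(=O)CCCCCCc2ccccc2)n1` carries a methylcarbamoyl group in that place, and in this assay compound 2 gives 1.8 nM. Compound 2 sits at the low end of the two numbers shown, but the step of a 1.7-fold lower number from compound 1 to compound 2 (0.22 log units; within the scatter) lies within the scatter, so the two compounds cannot be told apart on these data. Compound 3 `CN(C)C(=O)c1coc(C(=O)CCCCCCc2ccccc2)n1` differs from compound 2 by methyl in place of hydrogen on an amide-type nitrogen. Among the measured compounds shown here, no measured step touches this nitrogen; the only step known, a 1.7-fold lower number from compound 1 to compound 2 (0.22 log units; within the scatter), exchanged the whole ring substituent without moving the number beyond the scatter. Compound 3 is therefore expected to show a step of a 2.2-fold higher number from compound 2 to compound 3 (0.35 log units; beyond the scatter) in this assay, small if any. For compound 3 the estimate in this assay is 4 nM, between 1 nM and 15 nM.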

Compound 3, inhibition constant: 35 nM
Compound 3: the middle estimate sits 8.8-fold (0.94 log units) below what was measured, outside the stated range (above it).
By their numbers in this assay, from the lowest: compounds 2 and 1 (each within the scatter of the next); then compound 3.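

In this assay the amide-type nitrogen proves to be a sensitive place: methyl in place of hydrogen there gives a 19-fold higher number from compound 2 to compound 3 (1.29 log units; beyond the scatter) in a change of a single heavy atom. The earlier exchange of bromo for methylcarbamoyl stayed within the scatter, yet dimethylcarbamoyl in place of bromo on the aromatic carbon gives a 12-fold higher number from compound 1 to compound 3 (1.07 log units; beyond the scatter) in the same assay, so a carbamoyl group at this place is tolerated in one form and not in the other. Nothing available explains this step.

The compounds shown leave open whether an ethyl group on this nitrogen, or a pyrrolidine amide, would raise the number further or less. They also leave open how the unsubstituted carbamoyl group or a carboxylic acid on the aromatic carbon would compare with the methylcarbamoyl group.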